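This account rests on a few compounds, and the source may have more. Where it says the series, first, only, none or still open, it means among the compounds named here.

Compound 1 `CCN(CC)Cc1ccc2nc(NC(=O)N/N=C/c3cn(Cc4ccc(C)cc4)c4ccccc34)sc2c1`: 320 nM
Compound 2 `CCN(CC)Cc1ccc2nc(NC(=O)N/N=C/c3cn(Cc4ccc(Cl)cc4)c4ccccc34)sc2c1`: 370 nM

In a functional assay on NCI-H460 cells (Homo sapiens) for cytotoxicity, read by MTT assay, with a stated time of 72 h (on this read-out higher numbers stand for weaker inhibition and lower numbers for stronger inhibition), compound 2 gives 370 nM and stands within the scatter of compound 1, which gives 320 nM. The two cannot be ranked on these numbers.

Compound 3 `CCN(CC)Cc1ccc2nc(NC(=O)N/N=C/c3cn(Cc4ccc(Cl)c(Cl)c4)c4ccccc34)sc2c1` keeps everything in compound 2 except one spot, where the 4-chlorobenzyl becomes a 3,4-dichlorobenzyl: chloro in place of hydrogen on an aromatic carbon.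

Among the compounds with values here, only one measured step bears on this change, and only loosely. Within the data shown here, it put chloro in place of methyl on an aromatic carbon, whereas here chloro takes the place of hydrogen, and no measured compound shows that kind of change. With only a 1.2-fold higher number from compound 1 to compound 2 (0.06 log units; within the scatter) to go on, a step within the scatter, no step beyond the scatter is expected in this assay, and no direction can be favoured. The estimate therefore means a 1.2-fold lower number from compound 2 to compound 3 (0.06 log units; within the scatter), an expected change too small to separate from the scatter. For compound 3 the expected value is 320 nM, with an estimated range from 130 nM to 800 nM, kept wide because so little evidence bears on it.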

Compound 3, half-maximal inhibitory concentration: 610 nM
Beside the measured number, compound 3's estimate is 1.9-fold (0.28 log units) below it; the range from low to high includes it.
By their numbers in this assay, from the lowest: compounds 1, 2 and 3 (each within the scatter of the next).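

In this assay, a second chloro on the ring, ortho to the first, gives a 1.6-fold higher number from compound 2 to compound 3 (0.22 log units; within the scatter) and so shows that this carbon can carry a chloro instead of a hydrogen with no change that stands out from the scatter. Within the data shown here, earlier, the only comparison was chloro against methyl at a single spot, whereas the full change from 4-methylphenyl to 3,4-dichlorophenyl gives a 1.9-fold higher number from compound 1 to compound 3 (0.28 log units; within the scatter) and extends that picture to two ring positions, with all three compounds still too close to rank. Nothing measured here offers an explanation for these small differences.

The compounds shown all carry small groups on this ring, so it remains open whether a methoxy group, an amine or a carboxylic acid at the same carbon would give a step beyond the scatter. On these data alone, it also remains open how a 3-chlorobenzyl group, with no chloro at the other position, would compare, and so what each chloro contributes on its own.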